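The source may hold more compounds than are shown below. What is called first, only, known or untested is meant among the compounds shown, and "the series" means these compounds.

Measured compounds in a functional assay on LM7 cells (Homo sapiens) for cytotoxicity, read by MTT assay, with a stated time of 72 h; on this read-out lower numbers stand for stronger inhibition and higher numbers for weaker inhibition:
- compound 1, `Cc1nnc(SCc2coc3ccc(Cl)cc3c2=O)o1`: 8700 nM
- compound 2, `Cc1cc(C)n2nc(SCc3nnc(SCc4cc(=O)c5ccccc5o4)n3-c3ccccc3)nc2n1`: > 25000 nM
- compound 3, `Cc1cc(O)cc2oc(=O)cc(CSc3nc4ccccc4[nH]3)c12`: > 25000 nM

Among the compounds with values here, compound 1 is the only compound of the three to return a numerical value in this assay; it therefore defines the single fixed point of the series. Compound 2 returns a limit of the assay rather than a number. Compound 3 likewise returns a limit of the assay rather than a number. Taken together, the limit of > 25000 nM in this assay, at which 2 of the 3 values shown sit, describes where two of the three measured compounds sit, so no step between measured compounds can be computed and nothing about the size of any structural change has yet been read from data.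

Compound 4, `Cc1nnc(SCc2coc3ccc(Cl)cc3c2=O)s1`, has not been measured in this assay. It differs from compound 1 in one place: 5-methyl-1,3,4-thiadiazol-2-yl in place of 5-methyl-1,3,4-oxadiazol-2-yl on a sulfur. The change keeps the count of heavy atoms, donors and acceptors and exchanges only the ring heteroatom. Within the data shown here, with no measured step of this kind for guidance, the expectation is that this exchange moves the read-out by no more than the usual scatter, in either direction. Compound 4 is estimated to give 6500 nM, with a plausible range from 2500 nM to 20000 nM. The estimated step of a 1.3-fold lower number from compound 1 to compound 4 (0.13 log units; within the scatter) is expected to fall within the scatter.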

Compound 4, half-maximal inhibitory concentration: 7600 nM
The estimate for compound 4 lay 1.2-fold (0.07 log units) below the measured number, and the stated range covers the measured number.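

In this assay, within the data shown here, the exchange of 5-methyl-1,3,4-oxadiazol-2-yl for 5-methyl-1,3,4-thiadiazol-2-yl gives the only readable step: a 1.1-fold lower number from compound 1 to compound 4 (0.06 log units; within the scatter). At this place, on a sulfur whose other neighbours are saturated chain carbon, the two rings therefore cannot be told apart in this read-out, and the ring heteroatom, the only thing exchanged, shows no effect beyond the scatter in this single pair. The core of compound 1 now has two numerical values rather than one, which gives the place a first measured reference for further single changes, though one pair supports no wider rule.

Among these compounds, no steps involving compound 2 or compound 3 can be read, because each differs from the others in more than one place and each returns a limit of the assay rather than a number: the limit of > 25000 nM in this assay, at which 2 of the 4 values shown sit. Still open, on these data alone, is how far this place tolerates something other than a five-membered aromatic ring, for instance a morpholine, a carboxylic acid or a longer saturated chain on the sulfur.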